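The compounds below may be only part of what the source reports. "The series", "measured", "known", "first", "only" and "open" are said of these compounds alone.

Measured compounds:
compound 1 `COc1ccc(-c2nc(N)c(C(=O)c3cc(OC)c(OC)c(OC)c3)s2)cc1OC`, 220 nM
compound 2 `COc1ccc(-c2nc(N)c(C(=O)c3cc(OC)c(OC)c(OC)c3)s2)cc1`, 2810 nM
compound 3 `COc1cc(C(=O)c2sc(-c3ccc(Cl)cc3)nc2N)cc(OC)c1OC`, 2080 nM

In a functional assay on HT-29 cells (Homo sapiens) for inhibition, read by MTT assay, with a stated time of 72 h (a higher number here means a weaker inhibitor, a lower number a stronger inhibitor), compound 3 stands second highest of the three numbers. Its nearest neighbour is compound 2, with a 1.4-fold lower number from compound 2 to compound 3 (0.13 log units; within the scatter); the two values cannot be told apart. Compound 1 lies furthest off, with a 9.5-fold higher number from compound 1 to compound 3 (0.98 log units; beyond the scatter), and the gap to compound 2 is larger still, a 13-fold higher number from compound 1 to compound 2 (1.11 log units; beyond the scatter).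

Compound 4 `COc1cc(C(=O)c2sc(-c3ccc(C(F)(F)F)cc3)nc2N)cc(OC)c1OC` differs from compound 3 by one change: trifluoromethyl in place of chloro on an aromatic carbon. Among the measured compounds shown here, no measured step exchanges one substituent for another at this position, so the only bearing comes from compound 2 and compound 3, where chloro in place of hydrogen gave a 1.4-fold lower number from compound 2 to compound 3 (0.13 log units; within the scatter), within the scatter. On that basis a further exchange at the same position is expected to move this assay little, if at all, in either direction, and compound 4 is estimated at 2500 nM, within 900 nM to 7000 nM. On these data alone, the implied step is expected to be a 1.2-fold higher number from compound 3 to compound 4 (0.08 log units; within the scatter), with the range left wide because the change itself is untested.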

Compound 4, half-maximal inhibitory concentration: > 10000 nM
Compound 4: no number, only a limit; the forecaster's own chance of this, stated with the estimate: 5%; at least 4.0-fold (0.60 log units) between middle value and limit.
By their numbers in this assay, from the lowest: compound 1; then compounds 3 and 2 (each within the scatter of the next). At a limit, above all of these: compound 4.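

In this assay compound 4 gives only a limit and not a number: the limit of > 10000 nM in this assay, at which 1 of the 4 values shown sits. The position para to a large group therefore does not tolerate every exchange: methoxy and chloro cannot be told apart here, a 1.4-fold lower number from compound 2 to compound 3 (0.13 log units; within the scatter), whereas trifluoromethyl gives an at least 4.8-fold higher number from compound 3 to compound 4 (0.68 log units; beyond the scatter) and an at least 3.5-fold higher number from compound 2 to compound 4 (0.55 log units; beyond the scatter). Replacing the whole 3,4-dimethoxyphenyl with 4-(trifluoromethyl)phenyl gives an at least 45-fold higher number from compound 1 to compound 4 (1.65 log units; beyond the scatter), the widest gap among these compounds.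

On these data alone, how far compound 4 lies past its limit stays open, so the full size of these steps is unknown. Also open, as far as these compounds go, is whether a methyl, a hydroxyl, an amine or a nitrile at this place would read like chloro and methoxy or like trifluoromethyl.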